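A few compounds are considered here, and "the series" means these few. Any claim that something is new, unique, unknown or untested is made for them only; others in the source may bear on it.

Compound 1 `O=C(O)CCCSCCN1C(=O)OC[C@@H]1/C=C/[C@@H](O)Cc1ccccc1` is a ring-opened prostaglandin-like acid carrying a phenyl group at the end of its side chain. In an assay on CHO cells for displacement of a labelled ligand from prostaglandin E2 receptor EP1 subtype (Mus musculus), read by scintillation counting, with a stated time of 20 min (a lower number here means a stronger inhibitor, a higher number a weaker inhibitor), compound 1 reaches only the limit of the test, > 10000 nM, so no number is known for it. Compound 2 `CCCc1cccc(C[C@H](O)/C=C/[C@H]2CCC(=S)N2CCCCCCC(=O)O)c1`, built on a different core, also gives only a limit in this assay, > 10000 nM. Among the compounds with values here, both values therefore sit at the limit of > 10000 nM in this assay, at which 2 of the 2 values shown sit, and no measured step is available from which to read the size of any change. Compound 3 `O=C(O)CCCSCCN1C(=O)OC[C@@H]1/C=C/[C@@H](O)Cc1cccc(C(F)(F)F)c1` differs from compound 1 by trifluoromethyl in place of hydrogen on an aromatic carbon. Within the data shown here, with no measured step to guide it, the expectation for the move from compound 1 to compound 3 in this assay is a change of no more than an at least 1.2-fold lower number from compound 1 to compound 3 (0.09 log units; that floor lies within the scatter), and perhaps none beyond the scatter. Compound 3 is accordingly expected to give about 8000 nM, within a range from 1500 nM to 40000 nM.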

Compound 3, inhibition constant: > 10000 nM
Compound 3: only a limit was reported; the forecaster's own chance of this, stated with the estimate: 60%; at least 1.2-fold (0.09 log units) between middle value and limit.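

Compound 1 and compound 3 both stop at a limit of the test in this assay, so the step between them cannot be read: the limit of > 10000 nM in this assay, at which 3 of the 3 values shown sit.

The compounds shown leave open what actual number any of them would give, and whether trifluoromethyl in place of hydrogen changes it at all.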